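A few compounds are considered here, and "the series" means these few. Any claim that something is new, unique, unknown or untested is made for them only; others in the source may bear on it.

Measured in an ADME assay on BJ cells (Homo sapiens), read by MTT assay, with a stated time of 72 h; on this read-out lower numbers stand for stronger inhibition and higher numbers for weaker inhibition:

- compound 1 `CSc1ncnc2c1c(-c1ccccc1)cn2[C@@H]1O[C@H](CO)[C@@H](O)[C@H]1O`: > 100000 nM, a limit of the assay rather than a number
- compound 2 `Nc1nc2c(c(-c3cccs3)cn2[C@@H]2O[C@H](CO)[C@@H](O)[C@H]2O)c(=O)[nH]1`: > 100000 nM, again a limit
- compound 3 `C#Cc1cn([C@@H]2O[C@H](CO)[C@@H](O)[C@H]2O)c2nc(N)nc(OC)c12`: > 100000 nM, again a limit

Compound 1 therefore stands nowhere in particular on the measured numbers: its value is only a limit, and the same is true of compound 2 and of compound 3. Among the compounds with values here, no step between two measured compounds can be read off, since no measured pair differs in just one place.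

The step under consideration leads from compound 1 to compound 4 `COc1ncnc2c1c(-c1ccccc1)cn2[C@@H]1O[C@H](CO)[C@@H](O)[C@H]1O`. The change is methoxy in place of methylsulfanyl on an aromatic carbon: methylsulfanyl leaves and methoxy enters, on an aromatic carbon of a six-membered aromatic ring with two nitrogens within the fused system, next to the ring nitrogen.

Because the limit of > 100000 nM in this assay, at which 3 of the 3 values shown sit, is where every measured value sits, compound 4 is expected to show no step beyond the scatter, with a number no higher from compound 1 to compound 4 (the limit leaves the size open) as the expected change. Compound 4 is estimated at 100000 nM, most likely again as a limit, within a range from 30000 nM to 300000 nM.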

Compound 4, half-maximal inhibitory concentration: > 100000 nM
Compound 4 ended at the assay's limit; the forecaster's own chance of this, stated with the estimate: 85%; the middle value sits exactly at the limit.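

No step can be read from compound 1 to compound 4, because the values of both compounds are limits rather than numbers: the limit of > 100000 nM in this assay, at which 4 of the 4 values shown sit.

The compounds shown leave open how methoxy and methylsulfanyl compare in this assay, as none of them gives an actual number there.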